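The compounds below may be only part of what the source reports. "The series", "measured", "known", "first", "only" and "open" are said of these compounds alone.

Working notes on the series.

Compound 2 `COc1ncc(-c2ccc3ncnc(Nc4cnn(CCCO)c4)c3c2)cc1NS(=O)(=O)c1ccc(F)cc1F` is the reference point; in a functional assay on HCT-116 cells (Homo sapiens) for antiproliferative activity, read by sulforhodamine B assay, with a stated time of 72 h (a lower number here means a stronger inhibitor, a higher number a weaker inhibitor), compound 2 gives 480 nM. Compound 1 `COc1ncc(-c2ccc3ncnc(Nc4ccc(OCCO)cc4)c3c2)cc1NS(=O)(=O)c1ccc(F)cc1F` carries the change (4-(2-hydroxyethoxy)phenyl in place of 1-(3-hydroxypropyl)-1H-pyrazol-4-yl on a nitrogen on an aromatic ring). The step is a 2.2-fold higher number from compound 2 to compound 1 (0.34 log units; beyond the scatter), and in this assay compound 1 gives 1060 nM. Compound 3 `COc1ncc(-c2ccc3ncnc(Nc4cnn(CCCO)c4)c3c2)cc1NS(C)(=O)=O` differs from compound 2 by methyl in place of 2,4-difluorophenyl on a sulfonyl sulfur, and the step of a 3.0-fold higher number from compound 2 to compound 3 (0.47 log units; beyond the scatter) leaves compound 3 with 1420 nM in this assay. Compound 3 and compound 1 sit within the scatter of each other.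

Compound 4 `COc1ncc(-c2ccc3ncnc(Nc4ccc(OCCO)cc4)c3c2)cc1NS(C)(=O)=O` has not been measured in this assay. It differs from compound 3 by 4-(2-hydroxyethoxy)phenyl in place of 1-(3-hydroxypropyl)-1H-pyrazol-4-yl on a nitrogen on an aromatic ring, the same change as from compound 2 to compound 1, at the same place. The two cores differ by methyl in place of 2,4-difluorophenyl on a sulfonyl sulfur. Given a 2.2-fold higher number from compound 2 to compound 1 (0.34 log units; beyond the scatter), the step of a 2.0-fold higher number from compound 3 to compound 4 (0.31 log units; beyond the scatter) is expected to be of similar size, resting on that single earlier occurrence. For compound 4 in this assay the estimate is 2900 nM, with a range of 1400 nM to 6000 nM.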

Compound 4, half-maximal inhibitory concentration: 4860 nM
Beside the measured number, compound 4's estimate is 1.7-fold (0.22 log units) below it; low and high end bracket the measured number.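

In this assay, the change from 1-(3-hydroxypropyl)-1H-pyrazol-4-yl to 4-(2-hydroxyethoxy)phenyl on the nitrogen gives a 3.4-fold higher number from compound 3 to compound 4 (0.53 log units; beyond the scatter), and this matches its earlier occurrence on the core carrying 2,4-difluorophenyl: the same change on two cores in this assay, a 2.2-fold higher number (0.34 log units; beyond the scatter) from compound 2 to compound 1 and a 3.4-fold higher number (0.53 log units; beyond the scatter) from compound 3 to compound 4, 1.5-fold (0.19 log units) apart, within the scatter of two such steps. Methyl in place of 2,4-difluorophenyl on the sulfonyl sulfur gives a 4.6-fold higher number from compound 1 to compound 4 (0.66 log units; beyond the scatter), and this likewise matches its earlier occurrence: the same change on two cores in this assay, a 3.0-fold higher number (0.47 log units; beyond the scatter) from compound 2 to compound 3 and a 4.6-fold higher number (0.66 log units; beyond the scatter) from compound 1 to compound 4, 1.5-fold (0.19 log units) apart, within the scatter of two such steps. Across these four compounds, each change raises the number on both cores by a similar amount, so neither step shows a dependence on the other change, but each comparison rests on only one pair of steps and says nothing about cores outside this set.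

The compounds shown leave open whether the agreement holds for other groups on the sulfonyl sulfur, such as cyclopropyl or an unsubstituted phenyl. They also leave open what happens when an amine or a carboxylic acid replaces the hydroxyl of either chain, or when the 3-hydroxypropyl chain is lengthened.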